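From methoxy to ethoxy on the shared core

A few compounds are considered here, and "the series" means these few. Any claim that something is new, unique, unknown or untested is made for them only; others in the source may bear on it.

In an ADME assay on GM00637 cells (Homo sapiens) for cytotoxicity, read by MTT assay, with a stated time of 72 h (a lower number here means a stronger inhibitor, a higher number a weaker inhibitor), compound 1 (`O=c1cc2n(-c3ccccc3)nc(-c3ccccc3)nc-2cc1N1CCCCC1`) gives 1190 nM. Compound 2 (`COc1cc2nc(-c3ccccc3)nn(-c3ccccc3)c-2cc1=O`) gives > 5000 nM, which is a limit of the assay and not a number. Compound 3 (`CCOc1cc2nc(-c3ccccc3)nn(-c3ccccc3)c-2cc1=O`) carries ethoxy where compound 2 carries methoxy, a methyl in place of hydrogen on a saturated chain carbon bound to an oxygen on an aromatic ring. For the measured compounds named here, only one measured step bears on this change: an at least 4.2-fold higher number from compound 1 to compound 2 (0.62 log units; beyond the scatter), which lies beyond the scatter. That step exchanges piperidin-1-yl for methoxy, a different change from methoxy to ethoxy, so it offers only indirect guidance. No step beyond the scatter is therefore expected in this assay, in either direction. The expected change is a step that the limit leaves unreadable from compound 2 to compound 3. Compound 3 is estimated at 6000 nM, with an expected range from 2500 nM to 15000 nM.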

Compound 3, half-maximal inhibitory concentration: > 5000 nM
Compound 3: only a limit was reported; the forecaster's own chance of this, stated with the estimate: 65%; the middle value does not contradict the limit.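

In this assay compound 3 gives > 5000 nM, which is a limit of the assay and not a number. Exchanging piperidin-1-yl for ethoxy gives an at least 4.2-fold higher number from compound 1 to compound 3 (0.62 log units; beyond the scatter), so the higher number seen with methoxy at this position also holds for ethoxy. The step from compound 2 to compound 3 cannot be read, so the effect of adding the methyl remains unknown, because both compounds stand at the same limit: the limit of > 5000 nM in this assay, at which 2 of the 3 values shown sit.

The compounds shown leave open whether the lower number of compound 1, at 1190 nM, belongs to piperidin-1-yl alone or extends to other amines, such as dimethylamino or morpholin-4-yl, in the same place. They also leave open whether a hydroxyl group there would give a readable number.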